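A few compounds are considered here, and "the series" means these few. Any claim that something is new, unique, unknown or untested is made for them only; others in the source may bear on it.

Measured in a functional assay, read by spectrophotometry, with a stated time of 20 min; a higher number here means a weaker inhibitor, a lower number a stronger inhibitor:
- Compound 1 `Cc1c(-c2ccccc2)oc2ccccc2c1=O`: 106 ug/mL
- Compound 2 `Cc1ccccc1-c1oc2ccccc2c(=O)c1C`: 156 ug/mL
- Compound 3 `Cc1c(-c2ccc(Br)cc2)oc2ccccc2c1=O`: 111 ug/mL

In this assay compound 1 gives 106 ug/mL, which cannot be separated from the other two values, since repeat measurements of this kind naturally vary by about as much as these compounds differ.

Compound 4 `COc1ccc2c(=O)c(C)c(-c3ccccc3)oc2c1` is compound 1 with methoxy in place of hydrogen on an aromatic carbon. That carbon belongs to a six-membered aromatic ring of carbon only, part of a fused or bridged system of two rings.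

For the measured compounds named here, two measured steps bear on this change, each adding a single group to compound 1. Adding methyl gave a 1.5-fold higher number from compound 1 to compound 2 (0.17 log units; within the scatter), and adding bromo gave a 1.0-fold higher number from compound 1 to compound 3 (0.02 log units; within the scatter). Neither step lifted the number clear of the scatter, so adding a group to compound 1 has so far produced no measurable shift. Going by the values given here, this is only indirect guidance, as neither step involves methoxy and both were made on a different ring from the one that changes in compound 4. For that reason, the range has to stay wide.

The expected change is a 1.0-fold higher number from compound 1 to compound 4 (0.02 log units; within the scatter), so no step beyond the scatter is anticipated, in either direction. The estimate for compound 4 is 110 ug/mL, with an expected range of 60 ug/mL to 200 ug/mL.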

Compound 4, half-maximal inhibitory concentration: 200 ug/mL
Estimate against measurement, compound 4: 1.8-fold (0.26 log units) below, within the range that was stated.
By their numbers in this assay, from the lowest: compounds 1, 3, 2 and 4 (each within the scatter of the next).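

In this assay, placing methoxy on the ring of carbon only within the fused system gives a 1.9-fold higher number from compound 1 to compound 4 (0.28 log units; within the scatter). For the compounds shown here, this is the first measured change on that ring, and the step cannot be told apart from the ordinary variation between repeat measurements, so the result gives no sign that this carbon matters for inhibition in this assay, though one small group cannot settle the point. Together with the methyl and bromo steps on the other ring, it means that all three single additions to compound 1 shown so far stay within the scatter, with no compound among them standing out from compound 1, and nothing measured here offers an explanation for the size of this step.

On these data alone, what remains open is whether a different kind of group on this same carbon, such as an amine, a carboxylic acid or a longer chain like butoxy, would move the number clear of the scatter. It is also open whether methoxy on the other carbons of this ring would behave as it does here, since the compounds shown test this ring at only one place.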